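This account rests on a few compounds, and the source may have more. Where it says the series, first, only, none or still open, it means among the compounds named here.

The four compounds share one core and differ only in the group attached to the carbon that is double-bonded to nitrogen. Compound 1 `C/C(=N\c1nc(NC2CC2)c2ncn(C3C=CC(CO)C3)c2n1)c1ccc(O)cc1` carries one variant, and in a functional assay on CCRF-CEM cells (Homo sapiens) for cytotoxicity (on this read-out lower numbers stand for higher toxicity in this test and higher numbers for lower toxicity in this test), compound 1 gives 62000 nM. Compound 3 `O=C1Nc2ccc(F)cc2/C1=N\c1nc(NC2CC2)c2ncn(C3C=CC(CO)C3)c2n1` carries another, and in this assay compound 3 gives 56000 nM. Compound 2 `CN(C)c1ccc(/C=N/c2nc(NC3CC3)c3ncn(C4C=CC(CO)C4)c3n2)cc1` is the starting point of the step followed here. In this assay compound 2 reaches only a limit of the test, > 100000 nM, so no number is known for it, as recorded by the limit of > 100000 nM in this assay, at which 1 of the 3 values shown sits.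

Compound 4 `COc1ccc(/C=N/c2nc(NC3CC3)c3ncn(C4C=CC(CO)C4)c3n2)c(O)c1` has not yet been measured; it differs from compound 2 by 2-hydroxy-4-methoxyphenyl in place of 4-(dimethylamino)phenyl on a carbon with a double bond to nitrogen. For the measured compounds named here, no step between two measured compounds is available to size this change, and compound 2 itself offers only a limit rather than a number, so the direction of the step cannot be read from the data. What the measured numbers do show is that compound 1 gives 62000 nM and compound 3 gives 56000 nM, both weak. On that basis the step of an at least 1.4-fold lower number from compound 2 to compound 4 (0.15 log units; that floor lies within the scatter) is expected to be small, with a real chance that compound 4 also returns only a limit. Compound 4 is expected to give about 70000 nM, within a range from 30000 nM to 150000 nM.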

Compound 4, half-maximal cytotoxic concentration: 100000 nM
Beside the measured number, compound 4's estimate is 1.4-fold (0.15 log units) below it, within the range that was stated.
By their numbers in this assay, from the lowest: compounds 3, 1 and 4 (each within the scatter of the next).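

Exchanging 4-(dimethylamino)phenyl for 2-hydroxy-4-methoxyphenyl on a carbon with a double bond to nitrogen gives a number no higher from compound 2 to compound 4 (the limit leaves the size open) in this assay. Compound 4 gives an actual number, 100000 nM, which gives this aromatic group a real reading on the scale, and that reading still stands for low toxicity in this test, so this change does not bring a large gain in toxicity. How large the step is cannot be read, because its starting point is not a number: the limit of > 100000 nM in this assay, at which 1 of the 4 values shown sits.

Whether the hydroxy group, the methoxy group or only the two together account for the reading stays open, since the step exchanges a whole substituted ring at once. Also open, as far as these compounds go, is what a phenyl ring carrying a carboxylic acid or a primary amine, or a longer alkyl chain in place of the ring, would give at this place in this assay, and whether any such group would reach clearly lower numbers.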